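Cyclobutyl to cyclohexyl exchange in a hydroxylated side chain

The compounds below may be only part of what the source reports. "The series", "measured", "known", "first", "only" and "open" are said of these compounds alone.

compound 1 `N#Cc1cnc(NCc2cnccc2C(F)(F)F)cc1NC[C@H]1C[C@@H](O)C1` gives 84%
compound 2 `N#Cc1cnc(NCc2cnccc2C(F)(F)F)cc1N[C@H]1CC[C@@H](O)CC1` gives 33%
compound 3 `N#Cc1cnc(NCc2cnccc2C(F)(F)F)cc1NC[C@H]1CC[C@@H](O)CC1` gives 41%

In an ADME assay on S9 fraction from liver (Homo sapiens) for metabolic stability, with a stated time of 1 h (on this read-out higher numbers stand for a more stable compound and lower numbers for a less stable compound), compound 1 stands highest of the three measured compounds, and both steps from it lie beyond the scatter. Next is compound 4 `N#Cc1cnc(NCc2cnccc2C(F)(F)F)cc1NC[C@H]1CC[C@H](O)CC1` with the change 4-hydroxycyclohexyl in place of 3-hydroxycyclobutyl on a saturated chain carbon bound to a nitrogen on an aromatic ring on a saturated chain carbon bound to a nitrogen on an aromatic ring. The same exchange, in the same place, gave a number 43 percentage points lower from compound 1 to compound 3 (beyond the scatter) as the closest measured step. The 4-hydroxycyclohexyl group set directly on the nitrogen gave a number 51 percentage points lower from compound 1 to compound 2 (beyond the scatter) as a second large step, while a number 8 percentage points higher from compound 2 to compound 3 (within the scatter) stays within the scatter. A large downward step is therefore expected in this assay here. The expected step is a number 39 percentage points lower from compound 1 to compound 4 (beyond the scatter) on this estimate. Compound 4 is estimated at 45% with an expected range from 25% to 68% for the coming measurement.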

Compound 4, percent of the compound remaining: 32%
Beside the measured number, compound 4's estimate is 13 percentage points above it; the measured number falls inside the stated range.
By their numbers in this assay, from the lowest: compounds 4, 2 and 3 (each within the scatter of the next); then compound 1.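

In this assay, the large drop from the 3-hydroxycyclobutyl compound also holds for the other drawn configuration of the 4-hydroxycyclohexyl ring (a number 52 percentage points lower from compound 1 to compound 4 (beyond the scatter)). Moving from 4-hydroxycyclohexyl to (4-hydroxycyclohexyl)methyl on the nitrogen again stays within the scatter (a number 1 percentage points lower from compound 2 to compound 4 (within the scatter)). Inverting the configuration also leaves the number within the scatter (a number 9 percentage points lower from compound 3 to compound 4 (within the scatter)), and this pair tests configuration alone: the fact that compounds 3 and 4 differ only in the configuration as drawn

On these data alone, whether the high value of compound 1 depends on the four-membered ring or on its hydroxyl remains open. A (3-aminocyclobutyl)methyl group at this position would help to separate the two.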